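A few compounds are considered here, and "the series" means these few. Any claim that something is new, unique, unknown or untested is made for them only; others in the source may bear on it.

In a functional assay on MCF7 cells (Homo sapiens) for antiproliferative activity, read by CellTiter-Glo, with a stated time of 5 days (a lower number here means a stronger inhibitor, a higher number a weaker inhibitor), compound 1 `O=C(O)/C=C/c1ccc(/C(=C(\c2ccc(F)cc2Cl)C2CCC2)c2ccc3scnc3c2)cc1` gives 3 nM. Compound 3 `O=C(O)/C=C/c1ccc(/C(=C(\c2ncc(C(F)(F)F)cc2Cl)C2CCC2)c2ccc3scnc3c2)cc1`, at 2.9 nM, stands level with it, while compound 2 `N#Cc1ccc(/C(=C(\c2ccc(/C=C/C(=O)O)cc2)c2ccc3scnc3c2)C2CCC2)c(Cl)c1` gives 1.4 nM, the lowest number of the three. Compound 4 `O=C(O)/C=C/c1ccc(/C(=C(\c2ccc(F)cc2Cl)C2CCC2)c2ccc(-c3cncs3)cc2)cc1` changes a different part of the molecule: 4-(1,3-thiazol-5-yl)phenyl in place of 1,3-benzothiazol-5-yl on a double-bonded chain carbon bound to an aromatic carbon and a double-bonded chain carbon. The measured steps offer only indirect guidance. As far as these compounds go, both a 2.1-fold lower number from compound 1 to compound 2 (0.33 log units; beyond the scatter) and a 1.0-fold lower number from compound 1 to compound 3 (0.01 log units; within the scatter) are small, but neither replaces the 1,3-benzothiazol-5-yl group, so the effect of changing it remains untested. The expectation therefore leans cautiously towards weaker inhibition, with an expected step of a 2.7-fold higher number from compound 1 to compound 4 (0.43 log units; beyond the scatter). For compound 4, the estimated value is 8 nM, with an expected range from 2 nM to 30 nM.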

Compound 4, half-maximal inhibitory concentration: 4.2 nM
The estimate for compound 4 lay 1.9-fold (0.28 log units) above the measured number; the measured number falls inside the stated range.
By their numbers in this assay, from the lowest: compound 2; then compounds 3, 1 and 4 (each within the scatter of the next).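

In this assay the swap to 4-(1,3-thiazol-5-yl)phenyl in place of 1,3-benzothiazol-5-yl gives a 1.4-fold higher number from compound 1 to compound 4 (0.15 log units; within the scatter) and so stays within the scatter. Among these compounds, this is the first sign that this position, unchanged across the earlier compounds, tolerates a different arrangement of one five-membered aromatic ring and one six-membered aromatic ring of carbon only. No measurement available here accounts for this tolerance.

As far as these compounds go, it remains open how an amine or a plain phenyl would fare at this position. From the compounds shown here alone, whether the new group would keep its value alongside the nitrile of compound 2 is also open.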